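The source may hold more compounds than are shown below. What is called first, only, known or untested is meant among the compounds shown, and "the series" means these compounds.

Compound 1 `CC(C)(Oc1cccc(NC(=O)c2ccc(Oc3ccccc3)cc2)c1)C(=O)O` gives > 10000 nM in an assay on isolated protein for agonist activity at Bile acid receptor (Homo sapiens), read by TR-FRET, with a stated time of 3 h, in the absence of a further agent (a higher number here means that more compound is needed for the effect, a lower number that less compound is needed), a limit.
Compound 2 `COc1ccccc1C(=O)Nc1ccc(C)c(C(=O)O)c1` gives > 10000 nM in this assay, a limit.

Compound 2 therefore stands at the edge of this assay, as shown by the limit of > 10000 nM in this assay, at which 2 of the 2 values shown sit. Compound 3 `COc1ccccc1C(=O)Nc1cccc(C(=O)O)c1` differs from compound 2 by hydrogen in place of methyl on an aromatic carbon. Among the compounds with values here, no step between measured compounds is on record, so the expectation for this change rests only on compound 2 sitting at its limit. The step is expected to be small, in no clear direction, and a step that the limit leaves unreadable from compound 2 to compound 3 is the estimate. Compound 3 is expected to give 20000 nM, with a range from 5000 nM to 100000 nM, most probably again only a limit.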

Compound 3, half-maximal effective concentration: > 10000 nM
Compound 3 was reported as a limit; the forecaster's own chance of this, stated with the estimate: 85%; the middle value does not contradict the limit.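

Compound 2 and compound 3 are both reported only as limits, so no step between them can be read: the limit of > 10000 nM in this assay, at which 3 of the 3 values shown sit.

The compounds shown leave open the size and direction of any effect of replacing methyl with hydrogen in this assay.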